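Adding chloro beside the ketone in a thienopyridine series

A few compounds are considered here, and "the series" means these few. Any claim that something is new, unique, unknown or untested is made for them only; others in the source may bear on it.

Of the compounds shown here, two of one shared core have been measured in an assay on CHO cells for displacement of a labelled ligand from adenosine receptor A1 (Homo sapiens), tested at 10 uM; on this read-out higher numbers stand for more inhibition at the one concentration tested (going by the name of the read-out) and lower numbers for less inhibition. Going by the values given here, compound 1 `Nc1sc2cnccc2c1C(=O)c1ccccc1` is the unsubstituted parent; in this assay compound 1 gives 0%, the lowest of the two numbers known so far. Compound 2 `Nc1sc2cnccc2c1C(=O)c1ccc(Cl)cc1` carries chloro on the benzoyl ring, and in this assay compound 2 gives 50%. Among the compounds with values here, the one measured step is a number 50 percentage points higher from compound 1 to compound 2 (beyond the scatter), which stands well beyond the scatter.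

Compound 3 `Nc1sc2cnccc2c1C(=O)c1ccccc1Cl` is the remaining unmeasured case. Its change from compound 1 is chloro in place of hydrogen on an aromatic carbon. The same group enters as in the step to compound 2, but at a different carbon of the same ring, so that step bears on compound 3 only in part: it shows that chloro on this ring can lift the number strongly, while giving no direct reading for this placement. A rise is therefore expected, but a smaller and less certain one than in the step to compound 2. For compound 3 the expected result in this assay is 25%, between 0% and 55%, a step estimated as a number 25 percentage points higher from compound 1 to compound 3 (beyond the scatter).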

Compound 3, a percentage reported as inhibition, at one concentration (the size of the read-out at that concentration, not a potency): 0%
Estimate against measurement, compound 3: 25 percentage points above; the range from low to high includes it.
By their numbers in this assay, from the lowest: compounds 1 and 3 (each within the scatter of the next); then compound 2.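

In this assay, chloro placed ortho to a large group on the ring of compound 1 gives no change at the digits printed from compound 1 to compound 3 (within the scatter). Going by these compounds alone, the earlier step showed only that chloro on this ring can lift the number, and the new result shows that this does not hold at every carbon of the ring. The same group on the same ring gives two different results here: compound 2 gives 50%, whereas compound 3 gives 0%, so within this small set the place of the chloro matters as well as its presence. Nothing measured here gives a reason for the difference between these two placements.

From the compounds shown here alone, it remains open whether this place on the ring rejects substitution in general or only chloro, since a methoxy group or an amine ortho to a large group could either match compound 1 or lift the number. A reading at a single concentration is also not a potency, so the compounds shown leave open how compound 2 would compare with compound 3 across a range of concentrations.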